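A few compounds are considered here, and "the series" means these few. Any claim that something is new, unique, unknown or untested is made for them only; others in the source may bear on it.

Measured in a functional assay on HepG2 cells (Homo sapiens) for inhibition, read by MTT assay, with a stated time of 72 h; on this read-out higher numbers stand for weaker inhibition and lower numbers for stronger inhibition:
- compound 1 `Nc1nc2cc(-c3nn(CCCC(=O)NO)c4ncnc(N)c34)ccc2o1` gives > 50000 nM (a limit, not a number)
- compound 2 `Nc1nc2cc(-c3nn(CCCCCCCCCC(=O)NO)c4ncnc(N)c34)ccc2o1` gives 28600 nM 
- compound 3 `Nc1ncnc2c1c(-c1cnc3[nH]ccc3c1)nn2CCCCCCCCCC(=O)NO` gives 11700 nM 

Compound 2 stands highest of the two true numbers. The nearest number lies one step away (a 2.4-fold lower number from compound 2 to compound 3 (0.39 log units; beyond the scatter)), but that step changes the aromatic group, not the chain, and does not bear here.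

The change to compound 4 `Nc1nc2cc(-c3nn(CCC(=O)NO)c4ncnc(N)c34)ccc2o1` is hydroxycarbamoyl in place of 7-(hydroxycarbamoyl)heptyl on a saturated chain carbon, two bonds along the chain from an aromatic nitrogen and shortens the chain. Among the measured compounds shown here, the one relevant measured step is also a chain change (an at least 1.7-fold lower number from compound 1 to compound 2 (0.24 log units; that floor lies within the scatter)), and its true size remains open. In this assay a higher number is therefore expected (a 2.1-fold higher number from compound 2 to compound 4 (0.32 log units; beyond the scatter)), a modest estimated step that could be larger. A report only at the limit of > 50000 nM in this assay, at which 1 of the 3 values shown sits, is expected to be likely. The estimated value for compound 4 is 60000 nM (expected range 35000 nM to 120000 nM).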

Compound 4, half-maximal inhibitory concentration: > 150000 nM
Compound 4: no number, only a limit; the forecaster's own chance of this, stated with the estimate: 75%; middle value at least 2.5-fold (0.39 log units) away from the limit.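

In this assay, replacing 7-(hydroxycarbamoyl)heptyl with hydroxycarbamoyl at this place gives an at least 5.2-fold higher number from compound 2 to compound 4 (0.71 log units; beyond the scatter), so a chain change on the shared core now has an effect read as beyond the scatter, which the earlier chain step could not establish. Going by these compounds, compound 4 gives > 150000 nM, a limit and not a number, so the true size of this step stays open. The step between the two short-chain compounds cannot be read, as both carry limits.

On these data alone, whether a longer chain lowers the number further remains open. So does whether a carboxylic acid in place of the hydroxycarbamoyl end would retain the activity.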